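Side-Chain Swap on a Trimethoxyphenyl Triazole Phthalimide

The source may hold more compounds than are shown below. What is called first, only, known or untested is meant among the compounds shown, and "the series" means these compounds.

Compound 2 `COc1cc(-c2nnc(SCc3ccccc3Cl)n2N2C(=O)c3ccccc3C2=O)cc(OC)c1OC` was tested in a functional assay on HepG2 cells (Homo sapiens) for cytotoxicity, read by MTT assay, with a stated time of 48 h (on this read-out lower numbers stand for stronger inhibition and higher numbers for weaker inhibition), and there compound 2 reaches only the assay limit, > 200000 nM. Compound 1 `Cc1ccc(C(=O)CSc2nnc(C)n2N2C(=O)c3ccccc3C2=O)cc1` likewise gives only a limit in this assay, > 200000 nM. Both values sit at the limit of > 200000 nM in this assay, at which 2 of the 2 values shown sit, so neither compound can be ranked against the other. Compound 3 `COc1cc(-c2nnc(SCC(=O)c3ccc(C)cc3)n2N2C(=O)c3ccccc3C2=O)cc(OC)c1OC` differs from compound 2 by (4-methylphenyl)carbonyl in place of 2-chlorophenyl on a saturated chain carbon bound to a sulfur, the same chain that compound 1 carries. On that basis the step from compound 2 to compound 3 is expected to bring no change beyond the scatter, a number no higher from compound 2 to compound 3 (the limit leaves the size open). Compound 3 is therefore expected at 200000 nM, between 100000 nM and 400000 nM, most likely again reported only as a limit.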

Compound 3, half-maximal inhibitory concentration: 9440 nM
Compound 3: middle estimate off by 21-fold (1.33 log units), on the high side; measured number outside the range, below it.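

Changing 2-chlorobenzyl to ((4-methylphenyl)carbonyl)methyl on the sulfur brings an at least 21-fold lower number from compound 2 to compound 3 (1.32 log units; beyond the scatter) in this assay, so this position can move the read-out when 3,4,5-trimethoxyphenyl is present. The side chain alone does not account for this, since 3,4,5-trimethoxyphenyl in place of methyl on an aromatic carbon brings an at least 21-fold lower number from compound 1 to compound 3 (1.32 log units; beyond the scatter). Both steps are open-ended, and their sizes are minimums: the limit of > 200000 nM in this assay, at which 2 of the 3 values shown sit.

On these data alone, it remains open whether the carbonyl or the methyl of the new group carries the step. Also open, as far as these compounds go, is how an amine, a carboxylic acid or a longer chain would fare at this position.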